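This account rests on a few compounds, and the source may have more. Where it says the series, first, only, none or still open, it means among the compounds named here.

Measured so far:
compound 1 `CCCc1cnc2c(C#N)c(N3CCN(c4ncccn4)CC3)ccn12` — 248%
compound 2 `CC(C)(C)c1ccc(-c2ccn3c(CC(F)(F)F)cnc3c2C#N)cc1` — 272%
compound 3 `CCCc1cnc2c(C#N)c(N3CCN(c4nc(C)cc(C)n4)CC3)ccn12` — 179%

In a functional assay on CHO cells with metabotropic glutamate receptor 2 (Homo sapiens) as the target, read by GTPgammaS binding (a lower number here means a smaller maximal response, a higher number a larger maximal response), compound 1 stands second highest of the three: compound 2 sits higher, compound 3 lower, both beyond the scatter. Among the measured compounds shown here, the one single-point step measured in this set, a number 69 percentage points lower from compound 1 to compound 3 (beyond the scatter), concerns the 4,6-dimethylpyrimidin-2-yl in place of pyrimidin-2-yl on an amine nitrogen in a ring and leaves the chain on the core untouched.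

Compound 4 `CCc1cnc2c(C#N)c(N3CCN(c4ncccn4)CC3)ccn12` differs from compound 1 by hydrogen in place of methyl on a saturated chain carbon, two bonds along the chain from an aromatic carbon — propyl to ethyl. For the measured compounds named here, no measured step bears on this chain shortening; compound 2 carries a different chain on a different core substituent and gives no comparable pair. The expectation for this assay therefore rests on compound 1 alone, with a change of one carbon on the chain taken as small. The expected step is a number 10 percentage points lower from compound 1 to compound 4 (within the scatter), within the scatter. Compound 4 is estimated at 238%, in the range 190% to 285%.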

Compound 4, largest response reached (Emax), in percent of the reference or control that the assay uses: 214%
Compound 4: middle estimate off by 24 percentage points, on the high side; low and high end bracket the measured number.
By their numbers in this assay, from the lowest: compound 3; then compound 4; then compound 1; then compound 2.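

In this assay, the chain on the core proves to be a position that responds: a number 34 percentage points lower from compound 1 to compound 4 (beyond the scatter), so propyl to ethyl is not a silent change in this series. Earlier, only the group on the amine nitrogen in a ring had been shown to move the maximal response; now a single change at either place lowers the number from compound 1. Nothing available accounts for the drop on losing this one carbon.

Going by these compounds, whether a longer chain such as butyl would keep or raise the number relative to compound 1 stays open, since the direct comparison covers only propyl and ethyl. Also open, on these data alone, is whether the chain step holds with the 4,6-dimethylpyrimidin-2-yl group in place, which would show whether the two changes add up.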